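This account rests on a few compounds, and the source may have more. Where it says the series, first, only, none or still open, it means among the compounds named here.

Of the compounds shown here, three from this series have been measured in a functional assay on CHO cells with adenosine receptor A1 (Homo sapiens) as the target, read by cAMP accumulation and immunoassay, with a stated time of 6 min, tested at 0.1 uM; a lower number here means a stronger effect, a higher number a weaker effect of the compound at the concentration tested. Compound 1, with the structure `Nc1scc(CN2CCN(c3cccnc3)CC2)c1C(=O)c1ccc(Cl)cc1`, gives 3.4% in this assay. Compound 3, with the structure `Nc1scc(CN2CCN(c3c(F)cccc3F)CC2)c1C(=O)c1cccc(C(F)(F)F)c1`, gives 1.3%. Compound 2, with the structure `Nc1scc(CN2CCC(c3ccc(Cl)cc3)CC2)c1C(=O)c1ccc(Cl)cc1`, gives -2.3%. Compound 1 thus has the highest of the three numbers, but its distance to compound 3 and to compound 2 both lie within the scatter of repeated measurements, so no order among the three can be read from these values.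

Compound 4, with the structure `Nc1scc(CN2CCN(c3c(F)cc(F)cc3F)CC2)c1C(=O)c1ccc(Cl)cc1`, has not been measured. It differs from compound 1 in one place: 2,4,6-trifluorophenyl in place of pyridin-3-yl on an amine nitrogen in a ring. Because compound 1 gives 3.4% and the other two measured compounds give numbers within the scatter of it, the step from compound 1 to compound 4 is expected to be no larger than the scatter, in either direction, a number 1.4 percentage points lower from compound 1 to compound 4 (within the scatter). Compound 4 is therefore estimated to give 2% in this assay, with a range from -8% to 12%.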

Compound 4, a percentage reported as activity, at one concentration (the size of the read-out at that concentration, not a potency): -3.9%
Estimate against measurement, compound 4: 5.9 percentage points above, and the stated range covers the measured number.
By their numbers in this assay, from the lowest: compounds 4, 2, 3 and 1 (each within the scatter of the next).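

In this assay, for the compounds shown here, the exchange of pyridin-3-yl for 2,4,6-trifluorophenyl on the amine nitrogen in the ring provides the first direct comparison at this position, with a number 7.3 percentage points lower from compound 1 to compound 4 (within the scatter) as the step. This exchange removes the ring nitrogen and its hydrogen-bond acceptor and adds three fluorine atoms, yet the read-out does not move beyond the scatter, so neither aromatic ring can be placed ahead of the other. No measurement is available that explains this result. 

From the compounds shown here alone, it remains open whether a group of another kind on this nitrogen, such as a benzyl group, an acetyl group or a chain bearing a carboxylic acid, would give a step beyond the scatter. A single reading at one concentration also leaves open whether compound 1 and compound 4 differ in potency.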